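The source may hold more compounds than are shown below. What is called first, only, known or untested is meant among the compounds shown, and "the series" means these compounds.

The measured compounds:

Compound 1 `Cn1cncc1CN1CC(N(CC2CCN(C(=O)c3ccco3)CC2)S(=O)(=O)c2ccccn2)Cc2cc(C#N)ccc21`, which in an ADME assay on Caco-2 cells (Homo sapiens) for permeability, in the apical to basolateral direction (a higher number here means that the compound crosses the layer faster, a lower number that the compound crosses the layer more slowly), gives 0.5 10^-6 cm/s.
Compound 2 `Cn1cncc1CN1CC(N(CC2CCN(C(=O)CC(C)(C)C)CC2)S(=O)(=O)c2ccccn2)Cc2cc(C#N)ccc21`, which in this assay gives 0.5 10^-6 cm/s.

On these numbers compound 2 stands level with compound 1: the step of no change at the digits printed from compound 1 to compound 2 (within the scatter) lay within the scatter, and that step exchanged one group on the carbonyl carbon for another, with the rest of the molecule held fixed. Compound 3 `CC(C)C(=O)N1CCC(CN(C2Cc3cc(C#N)ccc3N(Cc3cncn3C)C2)S(=O)(=O)c2ccccn2)CC1` differs from compound 2 in the same place: isopropyl in place of neopentyl on a carbonyl carbon. Going by the values given here, the only measured step that bears on this change is the one from compound 1 to compound 2, and it was flat. For compound 3 the same kind of exchange on the carbonyl carbon is therefore expected to give no step beyond the scatter in this assay, that is no change at the digits printed from compound 2 to compound 3 (within the scatter). On that basis compound 3 is estimated at 0.5 10^-6 cm/s, with a range from 0.25 10^-6 cm/s to 1.2 10^-6 cm/s.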

Compound 3, apparent permeability: 0.5 10^-6 cm/s
Compound 3: the middle estimate sits on the measured number at the digits printed; low and high end bracket the measured number.
By their numbers in this assay, from the lowest: compounds 1, 2 and 3 (each within the scatter of the next).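

In this assay, isopropyl on the carbonyl carbon joins neopentyl and furan-2-yl without moving the read-out: the exchange for neopentyl gives a flat step (no change at the digits printed from compound 2 to compound 3 (within the scatter)), and the exchange for furan-2-yl gives another (no change at the digits printed from compound 1 to compound 3 (within the scatter)). Going by these compounds alone, the flat result at this place therefore now holds across three groups, including a pair of ring-free chains of different heavy-atom count, where the earlier compounds offered only a single step. Nothing available explains this flat behaviour.

The compounds shown leave open whether a carboxylic acid or an amine-bearing chain on the same carbonyl carbon would also stay within the scatter. They also leave open whether a change elsewhere on the shared core, such as at the nitrile, would move the number.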